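The source may hold more compounds than are shown below. What is called first, only, known or untested is meant among the compounds shown, and "the series" means these compounds.

Measured in a functional assay on K562 cells (Homo sapiens) for antiproliferative activity, read by MTT assay, with a stated time of 24 h; on this read-out higher numbers stand for weaker inhibition and lower numbers for stronger inhibition:
- Compound 1 `COc1ccc(C(=O)/C=C/c2cccc(F)c2)c2c1C=CC(C)(C)O2`: > 10000 nM (a limit)
- Compound 2 `COc1ccc(C(=O)/C=C/c2cccc([N+](=O)[O-])c2)c2c1C=CC(C)(C)O2`: 5870 nM
- Compound 3 `COc1ccc(C(=O)/C=C/c2ccc(Cl)c(Cl)c2)c2c1C=CC(C)(C)O2`: 9030 nM

Compound 3 stands level with compound 2 on these numbers, the gap being a 1.5-fold higher number from compound 2 to compound 3 (0.19 log units; within the scatter). The value of compound 1 is a limit and not a number.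

Compound 4 `COc1ccc(C(=O)/C=C/c2ccccc2Cl)c2c1C=CC(C)(C)O2` has yet to be measured in this assay. Its difference from compound 3 is 2-chlorophenyl in place of 3,4-dichlorophenyl on a double-bonded chain carbon bound to a double-bonded chain carbon. In words, 2-chlorophenyl takes the place of 3,4-dichlorophenyl on a double-bonded chain carbon bound to a double-bonded chain carbon. Within the data shown here, no measured compound carries the 2-chlorophenyl group, so the evidence is indirect. The nearest guides are the other changes to this phenyl group, an at least 1.1-fold lower number from compound 1 to compound 3 (0.04 log units; that floor lies within the scatter) and an at least 1.7-fold lower number from compound 1 to compound 2 (0.23 log units; that floor lies within the scatter). Neither shows a change beyond the scatter, so none is expected here either, though a limit reading remains possible for compound 4. The estimated step is a 1.1-fold lower number from compound 3 to compound 4 (0.05 log units; within the scatter). Compound 4 is estimated at 8000 nM, with an expected range from 3000 nM to 20000 nM.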

Compound 4, half-maximal inhibitory concentration: > 10000 nM
Compound 4 gave a limit, no number; the forecaster's own chance of this, stated with the estimate: 40%; at least 1.2-fold (0.09 log units) between middle value and limit.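

In this assay compound 4 gives a limit and not a number, which makes the 2-chlorophenyl group the second at this place, after the 3-fluorophenyl group of compound 1, to give no number: the limit of > 10000 nM in this assay, at which 2 of the 4 values shown sit. Against the two compounds with numbers, the result is an at least 1.1-fold higher number from compound 3 to compound 4 (0.04 log units; that floor lies within the scatter) and an at least 1.7-fold higher number from compound 2 to compound 4 (0.23 log units; that floor lies within the scatter), so neither floor shows this change moving the read-out beyond the scatter. Among the four compounds, only the 3-nitrophenyl and 3,4-dichlorophenyl groups give numbers at all.

The step between compound 1 and compound 4 cannot be read, both values being limits. From the compounds shown here alone, whether an amine or a hydroxyl group on this phenyl group, or a pyridine ring in its place, would give a number clearly apart from these remains open.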